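The source may hold more compounds than are shown below. What is called first, only, known or untested is meant among the compounds shown, and "the series" means these compounds.

Measured compounds:
Compound 1 `CCCCCCCCCC(=O)Nc1ccc(O)c2ccccc12` — 60000 nM
Compound 2 `CCC(=O)Nc1ccc(O)c2ccccc12` — "not determined" (no result reported)

In an assay on isolated protein for inhibition of histone acetyltransferase p300 (Homo sapiens), read by fluorescence, with a stated time of 5 min, in the presence of a further agent that is not named here (a higher number here means a weaker inhibitor, a lower number a stronger inhibitor), compound 1 gives 60000 nM, a weak result. For compound 2 this assay gives "not determined" (no result reported); no number stands for it, so compound 2 cannot be placed on the scale, and the only anchor for the shared core is the weak value of compound 1. Compound 3 `CS(=O)(=O)Nc1ccc(O)c2ccccc12` differs from compound 2 by methylsulfonyl in place of propanoyl on a nitrogen on an aromatic ring. For the measured compounds named here, with no measured step on hand, the expected change from compound 2 to compound 3 cannot be set from data; the writer expects no shift beyond the usual scatter in either direction, and a weak result for compound 3 in line with compound 1 given 60000 nM. For compound 3 in this assay the estimate is 60000 nM, expected to fall between 15000 nM and 250000 nM, with a real chance that only a limit is reported.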

Compound 3, half-maximal inhibitory concentration: 3000 nM
Beside the measured number, compound 3's estimate is 20-fold (1.30 log units) above it; measured number outside the range, below it.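

For the compounds shown here, no step from compound 2 to compound 3 can be read: compound 2 carries no number in this assay, while compound 3 gives 3000 nM. The compounds shown leave open what the change from propanoylamino to methanesulfonamido does by itself on the shared core. No evidence at hand bears on this result.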